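The source may report more compounds than this note shows. Statements on the series, on what has been measured and on what is new or still open speak of the compounds shown alone.

Measured compounds:
Compound 1, `COc1cc(/C=C/C(=O)Nc2ccccc2)ccc1OCCCCCN(C)C`, gives 1.61 in a physicochemical assay for lipophilicity, using the shake flask method, measured as octanol-water partition, at pH 7.4; on this read-out higher numbers stand for higher lipophilicity and lower numbers for lower lipophilicity.
Compound 2, `COc1cc(/C=C/C(=O)Nc2ccccc2)ccc1OCCCCCN1CCCC1`, gives 1.64 in this assay.

Compound 2 stands at the upper of the two numbers, but its nearest neighbour, compound 1, sits only a number 0.03 log units higher from compound 1 to compound 2 (within the scatter) away, so the two values cannot be told apart. The unmeasured compound 3, `COc1cc(/C=C/C(=O)Nc2ccccc2)ccc1OCCCCCCN(C)C`, differs from compound 2 in one place: (dimethylamino)methyl in place of pyrrolidin-1-yl on a saturated chain carbon, five bonds along the chain from an oxygen on an aromatic ring. Put differently, compound 3 is compound 1 with its chain lengthened by one saturated carbon before the nitrogen. Within the data shown here, only one measured step bears on this change, the one from compound 1 to compound 2, and it was a number 0.03 log units higher from compound 1 to compound 2 (within the scatter), within the scatter, even though the ring added carbon atoms. The present change removes the ring and adds a single chain carbon, so no step beyond the scatter is expected in this assay, with a slight lean upward because compound 1 already gave 1.61 with the shorter chain. Compound 3 is therefore estimated at 1.75, between 1.35 and 2.15, a step of a number 0.11 log units higher from compound 2 to compound 3 (within the scatter) that is expected to stay within the scatter.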

Compound 3, partition coefficient: 1.69
Estimate against measurement, compound 3: 0.06 log units above, and the stated range covers the measured number.
By their numbers in this assay, from the lowest: compounds 1, 2 and 3 (each within the scatter of the next).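

In this assay, replacing the pyrrolidin-1-yl ring with the open (dimethylamino)methyl group gives a number 0.05 log units higher from compound 2 to compound 3 (within the scatter) and so shows that, at this place on the chain, the ring is not needed to keep the number in the same range. Replacing dimethylamino with (dimethylamino)methyl, which adds one saturated carbon to the chain, gives a number 0.08 log units higher from compound 1 to compound 3 (within the scatter) and therefore cannot be told apart from repeat-to-repeat variation either. Together with the earlier step, this means that the three amine ends shown, whether ringed, open or carried on a chain one carbon longer, cannot be separated by this measurement, and nothing available here offers an explanation for that.

Going by these compounds, all three compounds end in an amine carried on a chain of similar length, so it remains open whether a much longer or much shorter chain would give a step beyond the scatter. A different end group, such as a morpholine, a piperidine or a carboxylic acid, is also untested by the compounds shown, and any of these could tell more about how much this position matters.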